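This account rests on a few compounds, and the source may have more. Where it says the series, first, only, none or still open, it means among the compounds named here.

Series notes. Compound 3 `CCN(CC)S(=O)(=O)c1ccc(NC(=O)C(C)(O)C(F)(F)F)cc1` holds the lowest of the numbers available in an assay on a protein complex (Cavia porcellus) with sulfonylurea receptors; K-ATP channels (Homo sapiens) as the target; a lower number here means a stronger inhibitor, a higher number a weaker inhibitor; compound 3 gives 810 nM. Compound 2 `Cn1nnnc1-c1ccc(NC(=O)C(C)(O)C(F)(F)F)cc1` gives 30900 nM in this assay. Compound 1 `CCC(C)N(C(C)CC)S(=O)(=O)c1ccc(NC(=O)C(C)(O)C(F)(F)F)cc1` returns only a limit in this assay, > 30000 nM, which is a limit and not a number (the limit of > 30000 nM in this assay, at which 1 of the 3 values shown sits). Compound 4 `CC(O)(C(=O)Nc1ccc([C@@H](O)c2ccccc2)cc1)C(F)(F)F` has not yet been measured in this assay. Its change from compound 3: hydroxy(phenyl)methyl in place of diethylsulfamoyl on an aromatic carbon. Among the compounds with values here, two measured steps bear on the group on this aromatic carbon. an at least 37-fold lower number from compound 1 to compound 3 (1.56 log units; beyond the scatter) shows that changing the amine on the sulfonyl sulfur alone spans the whole range of numbers seen. a 38-fold lower number from compound 2 to compound 3 (1.58 log units; beyond the scatter) shows an equally large gap when a different group stands on this aromatic carbon. The diethylsulfamoyl of compound 3 therefore stands alone at the low end, and both other groups tried there leave the number near the limit. Hydroxy(phenyl)methyl is neither a sulfamoyl nor a tetrazolyl, and no measured step covers it directly, which leaves wide uncertainty. For compound 4 the expected step is a 9.9-fold higher number from compound 3 to compound 4 (0.99 log units; beyond the scatter), a rise of the number in this assay. For compound 4 the estimate in this assay is 8000 nM, expected to lie between 1500 nM and 30000 nM.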

Compound 4, half-maximal inhibitory concentration: > 30000 nM
Compound 4 gave a limit, no number; the forecaster's own chance of this, stated with the estimate: 25%; at least 3.7-fold (0.57 log units) between middle value and limit.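

In this assay, hydroxy(phenyl)methyl in place of diethylsulfamoyl gives an at least 37-fold higher number from compound 3 to compound 4 (1.56 log units; beyond the scatter), so the same number of heavy atoms on this aromatic carbon does not preserve the low number of compound 3. Hydroxy(phenyl)methyl brings a six-membered aromatic ring of carbon only, a hydrogen-bond donor and a defined stereocentre, and it removes the sulfonyl group, yet the result is as poor as that of the sulfonamide compound 1. Among the groups tried on this carbon, therefore, only diethylsulfamoyl gives a number clearly clear of the limit, while compound 1 shows that a sulfamoyl group alone is not enough; compound 4 returns a limit and not a number, the step from compound 2 to compound 4 cannot be read, and the top of the range now holds two compounds: the limit of > 30000 nM in this assay, at which 2 of the 4 values shown sit.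

The compounds shown leave open whether benzoyl, with a carbonyl in place of the hydroxy-bearing carbon, or the opposite stereocentre of hydroxy(phenyl)methyl would bring the number down. They also leave open how far the amine on the sulfonyl sulfur can vary around diethylamino, for example as dimethylamino or pyrrolidine.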